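Replacing the group on sulfur in compound 1

The source may report more compounds than this note shows. Statements on the series, on what has been measured and on what is new or still open speak of the compounds shown alone.

In a functional assay on MGC-803 cells (Homo sapiens) for antiproliferative activity, read by MTT assay, with a stated time of 48 h (a lower number here means a stronger inhibitor, a higher number a weaker inhibitor), compound 1 (`COc1ccc(CN(C(=O)CSc2nc3ccc(OC)cc3s2)c2cc(OC)c(OC)c(OC)c2)cc1`) gives 1270 nM. That value lies within the usual scatter of two relatives: compound 2 (`COc1ccc(CN(C(=O)CCSc2nc3ccccc3o2)c2cc(OC)c(OC)c(OC)c2)cc1`) gives 640 nM, and compound 3 (`COc1ccc(CN(C(=O)CCCCSc2nc3ccccc3o2)c2cc(OC)c(OC)c(OC)c2)cc1`) gives 1360 nM.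

Compound 4 (`COc1ccc(CN(C(=O)CSc2nnnn2C)c2cc(OC)c(OC)c(OC)c2)cc1`) keeps the core of compound 1 and changes one group: 1-methyl-1H-tetrazol-5-yl in place of 6-methoxy-1,3-benzothiazol-2-yl on a sulfur. In words, 1-methyl-1H-tetrazol-5-yl stands in place of 6-methoxy-1,3-benzothiazol-2-yl on a sulfur.

Two measured steps offer indirect guidance. One exchanges the whole group on the saturated chain carbon bound to a carbonyl carbon, giving a 2.0-fold lower number from compound 1 to compound 2 (0.30 log units; within the scatter). The other alters the chain, giving a 2.1-fold higher number from compound 2 to compound 3 (0.33 log units; beyond the scatter). Within the data shown here, both are small, but no measured compound carries a tetrazole, so neither tests this replacement directly.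

A small step is therefore expected, with a tentative lean towards a higher number, since so much of the group departs. The expected change in this assay is a 2.0-fold higher number from compound 1 to compound 4 (0.29 log units; within the scatter). Compound 4 is estimated at 2500 nM, with an expected range from 800 nM to 8000 nM.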

Compound 4, half-maximal inhibitory concentration: 2490 nM
The estimate for compound 4 lay 1.0-fold (0.00 log units) above the measured number; low and high end bracket the measured number.
By their numbers in this assay, from the lowest: compounds 2, 1, 3 and 4 (each within the scatter of the next, the first and the last beyond it).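

In this assay, putting 1-methyl-1H-tetrazol-5-yl in place of 6-methoxy-1,3-benzothiazol-2-yl on a sulfur gives a 2.0-fold higher number from compound 1 to compound 4 (0.29 log units; within the scatter), so this pair cannot be told apart, even though the entering group has a single five-membered aromatic ring and no six-membered one. The comparison with the benzoxazole compound on the longer chain does separate, with a 3.9-fold higher number from compound 2 to compound 4 (0.59 log units; beyond the scatter), but that step alters the chain as well as the group on sulfur, so it cannot be pinned on the ring alone. Nothing available here gives a reason for either step.

As far as these compounds go, it remains open how a plain phenyl ring or a simple methyl on the sulfur would compare. Also open, from the compounds shown here alone, is whether 1-methyl-1H-tetrazol-5-yl would behave the same way on the longer chains of compound 2 and compound 3.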